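Thiophene in place of methoxyphenyl on the side chain

The source may report more compounds than this note shows. Statements on the series, on what has been measured and on what is new or still open speak of the compounds shown alone.

Three compounds have been measured in a functional assay on 1321-N1 cells for agonist activity at P2Y purinoceptor 2 (Homo sapiens), read by scintillation counting and inositol phosphate accumulation; on this read-out higher numbers stand for an effect only at larger amounts of compound and lower numbers for an effect already at smaller amounts:
compound 1, `O=C(O)CCCO/N=c1/ccn([C@@H]2O[C@H](COP(=O)(O)OP(=O)(O)OP(=O)(O)O)[C@@H](O)[C@H]2O)c(=O)[nH]1`: 299 nM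
compound 2, `O=c1[nH]/c(=N\OCCCc2ccc(Br)cc2)ccn1[C@@H]1O[C@H](COP(=O)(O)OP(=O)(O)OP(=O)(O)O)[C@@H](O)[C@H]1O`: 350 nM
compound 3, `COc1ccc(CCCO/N=c2/ccn([C@@H]3O[C@H](COP(=O)(O)OP(=O)(O)OP(=O)(O)O)[C@@H](O)[C@H]3O)c(=O)[nH]2)cc1`: 47 nM

Compound 3 stands lowest of the three, shown by a 6.4-fold lower number from compound 1 to compound 3 (0.80 log units; beyond the scatter) and by a 7.4-fold lower number from compound 2 to compound 3 (0.87 log units; beyond the scatter), both beyond the scatter, whereas compound 1 and compound 2 sit close together, with a 1.2-fold higher number from compound 1 to compound 2 (0.07 log units; within the scatter). Compound 4, `O=c1[nH]/c(=N\OCCCc2ccsc2)ccn1[C@@H]1O[C@H](COP(=O)(O)OP(=O)(O)OP(=O)(O)O)[C@@H](O)[C@H]1O`, differs from compound 3 by thiophen-3-yl in place of 4-methoxyphenyl on a saturated chain carbon, three bonds along the chain from an oxygen on an unsaturated carbon. Both steps that reached compound 3 bear on this change: the low number of compound 3 arrived only with the 4-methoxyphenyl group, and compound 2, carrying an aromatic ring without methoxy, stayed near compound 1. A thiophen-3-yl ring likewise lacks that methoxy, so a modest rise is expected in this assay, smaller than a full return to compound 2. Compound 4 is therefore estimated at 150 nM, within 55 nM to 400 nM, an expected 3.2-fold higher number from compound 3 to compound 4 (0.50 log units; beyond the scatter).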

Compound 4, half-maximal effective concentration: 103 nM
Compound 4: middle estimate off by 1.5-fold (0.16 log units), on the high side; the range from low to high includes it.
By their numbers in this assay, from the lowest: compound 3; then compound 4; then compounds 1 and 2 (each within the scatter of the next).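

In this assay, an aromatic ring without methoxy need not stay level with the carboxy compound, as thiophen-3-yl gives a lower number than carboxy (a 2.9-fold lower number from compound 1 to compound 4 (0.46 log units; beyond the scatter)) and 4-bromophenyl (a 3.4-fold lower number from compound 2 to compound 4 (0.53 log units; beyond the scatter)). Yet 4-methoxyphenyl still holds the lowest number at this place (a 2.2-fold higher number from compound 3 to compound 4 (0.34 log units; beyond the scatter)). Nothing shown explains these differences.

Going by these compounds, whether thiophen-2-yl or unsubstituted phenyl would come closer to 4-methoxyphenyl remains open. So does how an amine, or a longer chain carrying thiophen-3-yl, would read here.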